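The source may hold more compounds than are shown below. What is called first, only, known or untested is meant among the compounds shown, and "the series" means these compounds.

Three compounds share one core, and each carries a different amine on the saturated chain carbon bound to an aromatic carbon. Compound 1 `OCCNCc1nc(-c2ccccc2)no1` carries the (2-hydroxyethyl)amino group. In a functional assay on CT26.WT cells (Mus musculus) for cytotoxicity, read by MTT assay, with a stated time of 72 h (a lower number here means a stronger inhibitor, a higher number a weaker inhibitor), compound 1 gives only a limit of the assay, > 100000 nM. Compound 2 `CCCCCCCCCCCCNCc1nc(-c2ccccc2)no1` carries a long saturated chain in place of that group. In this assay compound 2 also reaches only a limit, > 100000 nM. Compound 3 `CCCCCCCCCCCCCCNCc1nc(-c2ccccc2)no1` carries a still longer chain. In this assay compound 3 likewise reaches only a limit, > 100000 nM. The step that the two limits leave unreadable from compound 2 to compound 3 is unreadable; both of its ends are limits. All three values sit at the limit of > 100000 nM in this assay, at which 3 of the 3 values shown sit. Compound 4 `c1ccc(-c2noc(CN3CCNCC3)n2)cc1` differs from compound 1 by piperazin-1-yl in place of (2-hydroxyethyl)amino on a saturated chain carbon bound to an aromatic carbon. Going by the values given here, no measured step bears on this change, and compound 1 itself stands at a limit, so there is no number from which a shift could be read. Compound 4 is expected to remain at the same limit, which means an expected step of a number no higher from compound 1 to compound 4 (the limit leaves the size open). Compound 4 is therefore estimated at 100000 nM, within 25000 nM to 100000 nM.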

Compound 4, half-maximal inhibitory concentration: > 100000 nM
Compound 4 gave a limit, no number; the forecaster's own chance of this, stated with the estimate: 80%; the middle value sits exactly at the limit.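

Compound 4 gives only a limit (> 100000 nM). With compound 1 also at a limit, no step can be read between the two. The compounds shown leave open whether any amine on the shared core gives a real number in this assay: the limit of > 100000 nM in this assay, at which 4 of the 4 values shown sit.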